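The source may report more compounds than this note shows. Statements on the series, on what has been measured and on what is new or still open speak of the compounds shown alone.

Measured in an ADME assay on HepG2 cells (Homo sapiens) for cytotoxicity, read by MTT assay, with a stated time of 72 h; on this read-out higher numbers stand for lower toxicity in this test and lower numbers for higher toxicity in this test:
- compound 1 `CC(C)Nc1nc2ccsc2c(=O)[nH]1`: 23900 nM
- compound 2 `CC(C)(C)Nc1nc2c(-c3ccc(F)cc3)csc2c(=O)[nH]1`: 2300 nM
- compound 3 `Cc1ccc(-c2csc3c(=O)[nH]c(NC(C)C)nc23)cc1`: 8800 nM

Compound 3 stands in the middle of these three numbers, under compound 1 and over compound 2. Compound 4 `CC(C)Nc1nc2c(-c3ccc(F)cc3)csc2c(=O)[nH]1` differs from compound 3 by one swap: fluoro in place of methyl on an aromatic carbon. In words, this is fluoro in place of methyl on an aromatic carbon, para to a large group.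

Among the measured compounds shown here, the only measured single-change step is a 2.7-fold lower number from compound 1 to compound 3 (0.43 log units; beyond the scatter), a modest one. It adds the whole 4-methylphenyl, so it says little about exchanging one atom on that ring. Compound 2 also carries the 4-fluorophenyl, though on a different chain, and gives 2300 nM. This hints at a slightly lower number, but little beyond the scatter is expected. The expected step is a 1.4-fold lower number from compound 3 to compound 4 (0.13 log units; within the scatter). For compound 4 the estimated value is 6500 nM, with an expected range of 2800 nM to 14000 nM.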

Compound 4, half-maximal cytotoxic concentration: > 15600 nM
Compound 4: only a limit was reported; the forecaster's own chance of this, stated with the estimate: 3%; middle value at least 2.4-fold (0.38 log units) away from the limit.
By their numbers in this assay, from the lowest: compound 2; then compound 3; then compound 1.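

In this assay, compound 4 gives only a limit, not a number: the limit of > 15600 nM in this assay, at which 1 of the 4 values shown sits. Fluoro in place of methyl on the ring brings an at least 1.7-fold higher number from compound 3 to compound 4 (0.24 log units; that floor lies within the scatter), so this swap shows no sign of raising toxicity in this test, though it cannot show a clear gain either. On the chain, hydrogen in place of methyl brings an at least 6.7-fold higher number from compound 2 to compound 4 (0.83 log units; beyond the scatter), a clear change tied to that one carbon, which shows the fluorophenyl compounds are not all alike here.

From the compounds shown here alone, the step between compound 1 and compound 4 cannot be read, so what the 4-fluorophenyl adds to the bare core stays open. Also open, going by these compounds, is how chloro or methoxy in the same ring place would read.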